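Shifting a Chloro Group Around the Ring

The source may report more compounds than this note shows. Statements on the series, on what has been measured and on what is new or still open speak of the compounds shown alone.

Compound 1, `Cc1cccc(COc2ccc(-c3cc(CN4CCN(Cc5ccc(C(F)(F)F)cc5)CC4)no3)cc2)c1`, gives 4000 nM in a functional assay on MCF7 cells (Homo sapiens) for antiproliferative activity, read by sulforhodamine B assay, with a stated time of 72 h; on this read-out lower numbers stand for stronger inhibition and higher numbers for weaker inhibition.
Compound 2, `Cc1ccc(COc2ccc(-c3cc(CN4CCN(Cc5ccc(C(F)(F)F)cc5)CC4)no3)cc2)cc1`, gives 1200 nM in this assay.
Compound 3, `FC(F)(F)c1ccc(CN2CCN(Cc3cc(-c4ccc(OCc5cccc(Cl)c5)cc4)on3)CC2)cc1`, gives 1400 nM in this assay.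

Among these three numbers compound 3 stands second highest. Its nearest neighbour is compound 2, with a 1.2-fold higher number from compound 2 to compound 3 (0.07 log units; within the scatter); its furthest is compound 1, with a 2.9-fold lower number from compound 1 to compound 3 (0.46 log units; beyond the scatter). Compound 4 is `FC(F)(F)c1ccc(CN2CCN(Cc3cc(-c4ccc(OCc5ccc(Cl)cc5)cc4)on3)CC2)cc1`. It differs from compound 3 only by 4-chlorophenyl in place of 3-chlorophenyl on a saturated chain carbon bound to an oxygen on an aromatic ring.

For the measured compounds named here, one measured step bears directly on this move: a 3.3-fold lower number from compound 1 to compound 2 (0.52 log units; beyond the scatter), the same relocation on the same ring, there of a methyl group, 3-methylphenyl replaced by 4-methylphenyl. That step was modest but beyond the scatter and went toward a lower number. The pair of compound 1 and compound 3 shows that chloro and methyl on this ring behave alike in this assay, so the relocation is expected to carry over. Compound 4 is therefore expected to show a lower number, with a step of about a 2.8-fold lower number from compound 3 to compound 4 (0.45 log units; beyond the scatter). The estimated value for compound 4 is 500 nM, ranging from 200 nM to 1400 nM.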

Compound 4, half-maximal inhibitory concentration: 6700 nM
The estimate for compound 4 lay 13-fold (1.13 log units) below the measured number; the whole stated range lies below it.
By their numbers in this assay, from the lowest: compounds 2 and 3 (each within the scatter of the next); then compounds 1 and 4 (each within the scatter of the next).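

In this assay, moving the chloro group from 3-chlorophenyl to 4-chlorophenyl gives the opposite direction to the same relocation of methyl (a 4.8-fold higher number from compound 3 to compound 4 (0.68 log units; beyond the scatter)), so the outcome of this change at this position depends on the group being moved. With both groups on 4-substituted rings, replacing methyl with chloro gives (a 5.6-fold higher number from compound 2 to compound 4 (0.75 log units; beyond the scatter)), whereas the pair carrying 3-methylphenyl and 4-chlorophenyl lies within the scatter (a 1.7-fold higher number from compound 1 to compound 4 (0.22 log units; within the scatter)). Replacing methyl with chloro therefore has no single effect on this ring: (the same change on two cores in this assay, a 2.9-fold lower number (0.46 log units; beyond the scatter) from compound 1 to compound 3 and a 5.6-fold higher number (0.75 log units; beyond the scatter) from compound 2 to compound 4, 16-fold (1.20 log units) apart, beyond the scatter of two such steps).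

Going by these compounds, whether fluoro or methoxy on this ring would follow the chloro pair, the methyl pair or neither remains open. The compounds shown also leave unexplained why chloro and methyl part ways under the same relocation.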